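The compounds below may be only part of what the source reports. "The series", "measured", "known", "first", "only" and "open" are said of these compounds alone.

Working notes on the series. The read-out used throughout is a functional assay on LS174T cells (Homo sapiens) for inhibition, with a stated time of 4 days, tested at 10 uM (a higher number here means a stronger effect of the compound at the concentration tested, a lower number a weaker effect), and three compounds have been measured in it. Compound 1 `Fc1cccc(F)c1C#Cc1ccc2nccc(Cl)c2c1` gives 89.7% in this assay. Compound 3 `Nc1ccnc2ccc(C#Cc3c(F)cccc3F)cc12` gives 93.9% in this assay, and the step of a number 4.2 percentage points higher from compound 1 to compound 3 (within the scatter) carries the change amino in place of chloro on an aromatic carbon and stays within the scatter. Compound 2 `Fc1cccc(F)c1C#Cc1ccc2c(Cl)ccnc2c1` gives 70.8% in this assay and holds the same atoms as compound 1 joined differently; the difference between the two cores is not broken down here. Compound 4 `Nc1ccnc2cc(C#Cc3c(F)cccc3F)ccc12` has not been measured in this assay. For the measured compounds named here, it differs from compound 2 by amino in place of chloro on an aromatic carbon and this is the same change as the one from compound 1 to compound 3, with the place described in the same words. The expectation for compound 4 rests on that one measured step, which stayed within the scatter in a number 4.2 percentage points higher from compound 1 to compound 3 (within the scatter) and so gives no reason to expect a large move from the reading of compound 2 at 70.8% in this assay. For compound 4 a step of similar size is expected, namely a number 4.2 percentage points higher from compound 2 to compound 4 (within the scatter) in this assay. Compound 4 is therefore estimated at 75% in this assay, with most repeat measurements expected between 62% and 88% in this assay.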

Compound 4, a percentage reported as inhibition, at one concentration (the size of the read-out at that concentration, not a potency): 97.7%
The estimate for compound 4 lay 22.7 percentage points below the measured number; the whole stated range lies below it.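

In this assay the replacement of chloro by amino gives a number 26.9 percentage points higher from compound 2 to compound 4 (beyond the scatter), and the size of this change does not carry from one core to the other: the same change on two cores in this assay, a number 4.2 percentage points higher (within the scatter) from compound 1 to compound 3 and a number 26.9 percentage points higher (beyond the scatter) from compound 2 to compound 4, 22.7 percentage points apart, beyond the scatter of two such steps

So in this series a step measured on the core of compound 1 is a poor guide to the step on the core of compound 2, and only one pair per core is available, which gives no rule for any further core. With compound 1 already at 89.7%, a read-out at one concentration may leave little room for a rise on that core, so these numbers do not show whether the two steps would also differ in potency.

Going by these compounds, it remains open how a methylamino or a morpholine group in place of chloro would read on either core. Also open, on these data alone, is whether the gap between the two cores would hold for such groups or is particular to amino.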